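Methoxy in place of fluoro: expectation for compound 4

The source may report more compounds than this note shows. Statements on the series, on what has been measured and on what is new or still open speak of the compounds shown alone.

Going by the values given here, compound 3 `Cc1c(C(=O)Nc2ccc(Oc3ccnc4[nH]ccc34)c(F)c2)nnn1-c1ccc(F)cc1` gives 150 nM in a functional assay on A549 cells (Homo sapiens) for cytotoxicity, read by MTT assay, with a stated time of 72 h (a lower number here means a stronger inhibitor, a higher number a weaker inhibitor), the lowest of the three numbers measured so far. Compound 1 `Cc1c(C(=O)Nc2ccc(Oc3ccnc4[nH]ccc34)c(F)c2)nnn1-c1ccccc1` gives 360 nM in this assay, and compound 2 `Cc1c(C(=O)Nc2ccc(Oc3ccnc4[nH]ccc34)c(F)c2)nnn1-c1ccccc1F` gives 390 nM; the step of a 1.1-fold higher number from compound 1 to compound 2 (0.03 log units; within the scatter) lies within the scatter. The step of a 2.4-fold lower number from compound 1 to compound 3 (0.38 log units; beyond the scatter) and the step of a 2.6-fold lower number from compound 2 to compound 3 (0.41 log units; beyond the scatter) both lie beyond it, so compound 3 stands as the strongest inhibitor of the three.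

Compound 4 `COc1ccc(-n2nnc(C(=O)Nc3ccc(Oc4ccnc5[nH]ccc45)c(F)c3)c2C)cc1` differs from compound 3 by methoxy in place of fluoro on an aromatic carbon. Among the compounds with values here, no measured step replaces fluoro by methoxy. The two steps that bear on this position, a 2.4-fold lower number from compound 1 to compound 3 (0.38 log units; beyond the scatter) and a 2.6-fold lower number from compound 2 to compound 3 (0.41 log units; beyond the scatter), concern placing a fluoro on the six-membered aromatic ring of carbon only, and both were modest. They show that a substituent at this place is tolerated without loss; they do not show what a methoxy does there. The expected step of a 1.5-fold higher number from compound 3 to compound 4 (0.17 log units; within the scatter) is therefore small, of no settled direction, and may well fall within the scatter. Compound 4 is estimated at 220 nM in this assay, with a range from 80 nM to 600 nM.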

Compound 4, half-maximal inhibitory concentration: 710 nM
Estimate against measurement, compound 4: 3.2-fold (0.51 log units) below; measured number outside the range, above it.
By their numbers in this assay, from the lowest: compound 3; then compounds 1, 2 and 4 (each within the scatter of the next).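

In this assay, the change from 4-fluorophenyl to 4-methoxyphenyl is a real one (step: a 4.7-fold higher number from compound 3 to compound 4 (0.68 log units; beyond the scatter)), so this place on the aromatic ring, para to a large group, responds to which group stands there and does not merely tolerate a substituent. Set against the unsubstituted phenyl, methoxy shows no separation (step: a 2.0-fold higher number from compound 1 to compound 4 (0.29 log units; within the scatter)), and the same holds against the 2-fluorophenyl group (step: a 1.8-fold higher number from compound 2 to compound 4 (0.26 log units; within the scatter)). Of the groups shown, the low number therefore belongs to 4-fluorophenyl alone, and putting a group at this place does not by itself give the step beyond the scatter that separates compound 3 from compound 1.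

The compounds shown offer no measurement that accounts for the difference between fluoro and methoxy at this place. As far as these compounds go, it remains open whether a chloro or a trifluoromethyl at the same place would stand with fluoro, and whether a hydroxyl, an amine or a longer chain such as ethoxy would stand with methoxy.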